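Swapping a small methyl for a cyclopropyl cap

The source may hold more compounds than are shown below. What is called first, only, known or untested is meant among the compounds shown, and "the series" means these compounds.

Measured so far:
compound 1 `Cc1cc(NC(=O)Cn2nnc(-c3ccccc3)n2)n(C2CCCCC2)n1` — 92%
compound 2 `Cc1cc(NC(=O)Cn2nnc(-c3ccccc3)n2)n(C2CCC(F)(F)CC2)n1` — 68%
compound 3 `Cc1cc(NC(=O)Cn2nnc(-c3ccccc3)n2)n(C2CC2)n1` — > 78%

In an assay on HEK293 cells for activation of Kir3.1/Kir3.2 (Homo sapiens), read by thallium flux (a higher number here means a larger maximal response, a lower number a smaller maximal response), compound 1 gives 92% and stands highest of the two numbers shown. Compound 2, which carries a 4,4-difluorocyclohexyl group in place of cyclohexyl on the aromatic nitrogen, gives 68%; the step of a number 24 percentage points lower from compound 1 to compound 2 (beyond the scatter). For compound 3 the result is a limit of the assay rather than a number, > 78%, and this is the line (the limit of > 78% in this assay, at which 1 of the 3 values shown sits). That leaves the step that the limit leaves unreadable from compound 1 to compound 3, while the step of a number at least 10 percentage points higher from compound 2 to compound 3 (that floor lies within the scatter).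

Compound 4 `CC1(c2cc(NC(=O)Cn3nnc(-c4ccccc4)n3)n(C3CCCCC3)n2)CC1` changes a different place on the shared core: 1-methylcyclopropyl in place of methyl on an aromatic carbon. None of the three measured steps alters this position; all of them exchange the group on the aromatic nitrogen. So no measured step speaks directly to the change from compound 1 to compound 4. Going by the values given here, the only guide is that the two exchanges on the nitrogen either left the maximal response unreadable or moved it modestly. On that basis a step within the scatter, or at most a modest one downward, is expected, and the value of compound 4 is estimated at 84% with a range from 62% to 100%, which as a step means a number 8 percentage points lower from compound 1 to compound 4 (within the scatter) is expected.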

Compound 4, largest response reached (Emax), in percent of the reference or control that the assay uses: > 10%
Compound 4: only a limit was reported; the forecaster's own chance of this, stated with the estimate: 10%; the middle value does not contradict the limit.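

Compound 4 gives > 10%, which is a limit and not a number. The step from compound 1 to compound 4 cannot be read, because the result is only this: the limit of > 10% in this assay, at which 1 of the 4 values shown sits.

The compounds shown leave open whether 1-methylcyclopropyl in place of methyl on the aromatic carbon raises, lowers or leaves unchanged the maximal response.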